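Replacing a Carbamate with Butyl on the Aryl Ring

This account rests on a few compounds, and the source may have more. Where it says the series, first, only, none or still open, it means among the compounds named here.

Two compounds have so far been run in a functional assay on cells (Splenocyte, Mus musculus, strain BALB/c) for inhibition, read by scintillation counting and thymidine incorporation, with stated times of 48 h and 8 h; on this read-out higher numbers stand for weaker inhibition and lower numbers for stronger inhibition. Compound 1 `CCc1ccc(-c2noc(Cc3c[nH]c4ccccc34)n2)cc1` gives 7500 nM in this assay. Compound 2 `COc1cc(-c2noc(-c3ccc(NC(=O)OC(C)(C)C)cc3)n2)cc(OC)c1OC` gives 1600 nM in this assay, the lower of the two numbers, and compound 1 stands beyond the scatter above it, so compound 2 is the stronger inhibitor of the pair. Compound 3 `CCCCc1ccc(-c2nc(-c3cc(OC)c(OC)c(OC)c3)no2)cc1` has not yet been measured. It differs from compound 2 in one place: butyl in place of (tert-butoxycarbonyl)amino on an aromatic carbon. Going by the values given here, no measured pair shows this exact change, so its effect on the read-out is unknown. The only related hint is that compound 1, whose aryl ring carries a short alkyl chain rather than the carbamate, gives 7500 nM. On that thin basis the expected step is a 2.2-fold higher number from compound 2 to compound 3 (0.34 log units; beyond the scatter), toward weaker inhibition and probably beyond the scatter. Compound 3 is estimated at 3500 nM, within a range from 900 nM to 14000 nM.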

Compound 3, half-maximal inhibitory concentration: > 50000 nM
Compound 3: no number, only a limit; the forecaster's own chance of this, stated with the estimate: 10%; middle value at least 14-fold (1.15 log units) from the limit.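

Compound 3 has no number in this assay, only a limit of the assay: the limit of > 50000 nM in this assay, at which 1 of the 3 values shown sits.

On this aromatic carbon, para to a large group, butyl in place of (tert-butoxycarbonyl)amino gives an at least 31-fold higher number from compound 2 to compound 3 (1.49 log units; beyond the scatter), a large step. Going by these compounds alone, the earlier two compounds differ in more than one place and offered no single-change step, so this is the first reading to show that the group at this position matters strongly to inhibition on this read-out.

The compounds shown leave open which part of the (tert-butoxycarbonyl)amino group carries this difference: the amide hydrogen, the carbonyl or the tert-butyl end. On these data alone, it also remains open whether a free amine or an acetamide on the same aromatic carbon would give a number close to that of compound 2 or one as weak as the limit of compound 3.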